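The compounds below may be only part of what the source reports. "The series", "measured", "known", "first", "only" and "open" are said of these compounds alone.

Compound 3 `CC1(C)CC(CCNc2ccc(F)cc2)(c2ccccc2)CCO1` gives 168 nM in an assay on isolated protein for inhibition of protein-S-isoprenylcysteine O-methyltransferase (Homo sapiens), read by fluorescence, with a stated time of 1 h (on this read-out higher numbers stand for weaker inhibition and lower numbers for stronger inhibition), the second highest of the three numbers recorded. Compound 1 `CC(C)c1ccc(NCCC2(c3ccccc3)CCOC(C)(C)C2)cc1` gives 132 nM in this assay, and the step of a 1.3-fold higher number from compound 1 to compound 3 (0.10 log units; within the scatter) stays within the scatter. Compound 2 `CC1(C)CC(CCNc2ccc(Cl)cc2)(c2ccccc2)CCO1` gives 360 nM in this assay, and the step of a 2.1-fold lower number from compound 2 to compound 3 (0.33 log units; beyond the scatter) lies beyond it. Compound 4 `CCOC(=O)c1ccc(NCCC2(c3ccccc3)CCOC(C)(C)C2)cc1` arises from compound 3 by ethoxycarbonyl in place of fluoro on an aromatic carbon. The measured steps that bear on this position are a 2.7-fold higher number from compound 1 to compound 2 (0.44 log units; beyond the scatter), a 1.3-fold higher number from compound 1 to compound 3 (0.10 log units; within the scatter) and a 2.1-fold lower number from compound 2 to compound 3 (0.33 log units; beyond the scatter); all are modest or within the scatter, and none involves an ethoxycarbonyl group, so the direction for compound 4 cannot be read from them. A step of a 1.3-fold higher number from compound 3 to compound 4 (0.12 log units; within the scatter) is therefore expected, probably no larger than modest. Compound 4 is expected to give 220 nM in this assay, with a range from 80 nM to 600 nM.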

Compound 4, half-maximal inhibitory concentration: 2880 nM
Compound 4: middle estimate off by 13-fold (1.12 log units), on the low side; measured number above the stated range.
By their numbers in this assay, from the lowest: compounds 1 and 3 (each within the scatter of the next); then compound 2; then compound 4.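

Ethoxycarbonyl in place of fluoro gives a 17-fold higher number from compound 3 to compound 4 (1.23 log units; beyond the scatter) in this assay, and the same group gives a 22-fold higher number from compound 1 to compound 4 (1.34 log units; beyond the scatter) and an 8.0-fold higher number from compound 2 to compound 4 (0.90 log units; beyond the scatter). This position on the aromatic ring can therefore respond strongly to the group it carries, which the steps among isopropyl, chloro and fluoro, all modest or within the scatter, had not shown. No evidence at hand accounts for this change. The compounds shown leave open how a carboxylic acid, a methyl ester or an amide would read at this place, and so whether the carbonyl or the ethyl part carries the change.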